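The source may report more compounds than this note shows. Statements on the series, on what has been measured and on what is new or still open speak of the compounds shown alone.

Compound 1 `O=C(/C=C/c1ccc(OCc2cn(Cc3ccccc3Br)nn2)cc1)c1ccc(Br)cc1` gives 44% in a functional assay on MCF7 cells (Homo sapiens) for inhibition, read by MTT assay, with a stated time of 48 h, tested at 10 uM; on this read-out higher numbers stand for more inhibition of growth at the one concentration tested and lower numbers for less inhibition of growth.
Compound 2 `O=C(/C=C/c1ccc(OCc2cn(Cc3ccc(F)cc3)nn2)cc1)c1ccc(Br)cc1` gives 37% in this assay.
Compound 3 `COc1ccc(C(=O)/C=C/c2ccc(OCc3cn(Cc4ccccc4Br)nn3)cc2)cc1` gives 60% in this assay.

Of these three, compound 3 stands highest: the step of a number 16 percentage points higher from compound 1 to compound 3 (beyond the scatter) lies beyond the scatter, and the value of compound 2 lies lower still. Compound 4 `COc1ccc(C(=O)/C=C/c2ccc(OCc3cn(Cc4cccc(F)c4)nn3)cc2)cc1` differs from compound 3 in one place, on a saturated chain carbon bound to an aromatic nitrogen: 3-fluorophenyl in place of 2-bromophenyl on a saturated chain carbon bound to an aromatic nitrogen. Going by the values given here, one measured step bears on this kind of exchange, a number 7 percentage points lower from compound 1 to compound 2 (within the scatter), which stays within the scatter, though there the fluorine entered as 4-fluorophenyl rather than 3-fluorophenyl. On that basis no step beyond the scatter is expected in this assay, with at most a slight lean downward, a number 7 percentage points lower from compound 3 to compound 4 (within the scatter). Compound 4 is therefore estimated at 53%, between 35% and 68%.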

Compound 4, percent growth inhibition at one concentration: 41%
Compound 4: middle estimate off by 12 percentage points, on the high side, and the stated range covers the measured number.
By their numbers in this assay, from the lowest: compounds 2, 4 and 1 (each within the scatter of the next); then compound 3.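

In this assay, the change from 2-bromophenyl to 3-fluorophenyl on a saturated chain carbon bound to an aromatic nitrogen gives a number 19 percentage points lower from compound 3 to compound 4 (beyond the scatter). So this position can move the number beyond the scatter, which a number 7 percentage points lower from compound 1 to compound 2 (within the scatter) did not show; that earlier pair carries bromo rather than methoxy on the other aromatic ring and has 4-fluorophenyl as the entering group.

The compounds shown leave open whether the halogen or its place on the ring matters, and how an amine on that phenyl ring would read. Nothing measured here accounts for the step.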